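Ester Variation at the Side Chain and Cell Toxicity

A few compounds are considered here, and "the series" means these few. Any claim that something is new, unique, unknown or untested is made for them only; others in the source may bear on it.

Measured compounds:
- compound 1, `C=CCn1c(=O)c(CCO)c(-c2ccccc2Cl)c2cc(Cl)ccc21`: 23000 nM
- compound 2, `CC(C)C(=O)OCCc1c(-c2ccccc2Cl)c2cc(Cl)ccc2[nH]c1=O`: 62000 nM

Of the compounds shown here, two have been tested in an ADME assay on HepG2 2.2.15 cells (Homo sapiens) for cytotoxicity; on this read-out lower numbers stand for higher toxicity in this test and higher numbers for lower toxicity in this test. Compound 1, the one with the free hydroxyethyl side chain, gives 23000 nM. Compound 2, which carries an ester on that side chain, gives 62000 nM, the higher of the two numbers; it lies above compound 1 by a step that is beyond the usual scatter, so compound 2 is the less toxic of the pair in this assay.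

Compound 3, `CC(=O)OCC(=O)OCCc1c(-c2ccccc2Cl)c2cc(Cl)ccc2[nH]c1=O`, has not yet been measured. It differs from compound 2 only in the ester portion: acetoxymethyl in place of isopropyl on a carbonyl carbon. The shared core and the rest of the molecule are unchanged. Within the data shown here, no measured pair shows the effect of this particular exchange, so the expectation rests on compound 2 alone. Since both measured numbers sit in the same broad region, the step from compound 2 to compound 3 is expected to be small, a 1.1-fold lower number from compound 2 to compound 3 (0.05 log units; within the scatter), in no clear direction beyond the scatter. Compound 3 is therefore estimated at 55000 nM in this assay, with a range of 22000 nM to 140000 nM.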

Compound 3, half-maximal cytotoxic concentration: 100000 nM
Estimate against measurement, compound 3: 1.8-fold (0.26 log units) below; the measured number falls inside the stated range.
By their numbers in this assay, from the lowest: compound 1; then compounds 2 and 3 (each within the scatter of the next).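

In this assay, replacing isopropyl with acetoxymethyl on a carbonyl carbon gives a 1.6-fold higher number from compound 2 to compound 3 (0.21 log units; within the scatter). Among these compounds, this is the first direct comparison at this position, and it shows that a change from a small branched carbon group to acetoxymethyl, which brings hydrogen-bond acceptors and a further carbonyl group, does not move the number beyond the usual scatter. In practical terms, compound 3 and compound 2 cannot be told apart in this test, so this exchange shows no clear change in cell toxicity. Nothing available explains why the result came out this way.

Compound 1 differs from compound 2 and compound 3 in more than one place, so the effect of the ester itself on the side chain cannot be read from these compounds. As far as these compounds go, it also remains open whether a different group on the same carbonyl carbon, such as an aminomethyl group, a carboxylic acid or a longer carbon chain, would shift the number beyond the scatter.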